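From pyridin-3-yl to pyridin-2-yl on the same chain carbon

This account rests on a few compounds, and the source may have more. Where it says the series, first, only, none or still open, it means among the compounds named here.

Values in an ADME assay (liver) for pharmacokinetics, with Liver microsome (Rattus norvegicus) as the target, read by LC-MS, using microsomes, tested at 2 uM; on this read-out lower numbers stand for slow clearance and higher numbers for fast clearance:
compound 1 `COCCOc1ncc(C(=O)N[C@@H]2CCCC[C@H]2O)cc1-c1ccc(Cl)cc1`: 0.098 mL/min/kg
compound 2 `O=C(N[C@@H]1CCCC[C@H]1O)c1cnc(OCc2cccnc2)c(-c2ccc(Cl)cc2)c1`: 0.374 mL/min/kg

Of the two measured compounds, compound 2 has the higher number, 0.374 mL/min/kg. Within the data shown here, the only measured step is a 3.8-fold higher number from compound 1 to compound 2 (0.58 log units; beyond the scatter), with pyridin-3-yl in place of methoxymethyl on a saturated chain carbon bound to an oxygen on an aromatic ring.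

Compound 3 `O=C(N[C@@H]1CCCC[C@H]1O)c1cnc(OCc2ccccn2)c(-c2ccc(Cl)cc2)c1` has not yet been measured. Its change is pyridin-2-yl in place of pyridin-3-yl on a saturated chain carbon bound to an oxygen on an aromatic ring. Among the measured compounds shown here, the two have the same atoms, joined differently, and no measured step compares two pyridinyl groups. For the measured compounds named here, the one step available exchanges a different group, so it bears only indirectly, yet its size argues for a wide range. No step beyond the scatter is expected in this assay. The expected step is a 1.2-fold lower number from compound 2 to compound 3 (0.10 log units; within the scatter). Compound 3 is estimated at 0.3 mL/min/kg, with an expected range of 0.12 mL/min/kg to 0.75 mL/min/kg.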

Compound 3, clearance: 0.044 mL/min/kg
Compound 3: middle estimate off by 6.8-fold (0.83 log units), on the high side; measured number outside the range, below it.
By their numbers in this assay, from the lowest: compound 3; then compound 1; then compound 2.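

In this assay, pyridin-2-yl in place of pyridin-3-yl on a saturated chain carbon bound to an oxygen on an aromatic ring gives an 8.5-fold lower number from compound 2 to compound 3 (0.93 log units; beyond the scatter) even though the two groups have the same atoms, so at this position the way the pyridine is joined matters and not only its presence. Against methoxymethyl, the two pyridinyl groups pull in opposite directions, with a 3.8-fold higher number from compound 1 to compound 2 (0.58 log units; beyond the scatter) for pyridin-3-yl but a 2.2-fold lower number from compound 1 to compound 3 (0.35 log units; beyond the scatter) for pyridin-2-yl, so the earlier step cannot stand for pyridine rings at this position in general. Nothing shown gives a reason for the gap between the two groups.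

From the compounds shown here alone, whether pyridin-4-yl or a plain phenyl would fall with pyridin-2-yl or with pyridin-3-yl remains open. So does the effect of adding an amine to the pyridin-2-yl ring.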